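The source may hold more compounds than are shown below. What is called first, only, known or untested is meant among the compounds shown, and "the series" means these compounds.

Compound 3 `CCOC(=O)c1c(C)nc(-c2cccc(C#N)c2)n1OCCC(=O)O` carries a carboxymethyl group on a saturated chain carbon bound to an oxygen on the shared core. In a functional assay on a cell-free system (plasma, Oryctolagus cuniculus) for inhibition, with stated times of 5 min, 1 min and 6 min (on this read-out lower numbers stand for stronger inhibition and higher numbers for weaker inhibition), compound 3 gives only a limit, > 30000 nM, and no number. That places compound 3 at the limit of > 30000 nM in this assay, at which 1 of the 3 values shown sits. Compound 1 `CCOC(=O)COn1c(-c2cccc(C#N)c2)nc(C)c1C(=O)OCC` gives 6800 nM in this assay, and compound 2 `CCOC(=O)c1c(C)nc(-c2cccc(C#N)c2)n1OCCCO` gives 11400 nM. The steps toward the acid were an at least 4.4-fold higher number from compound 1 to compound 3 (0.64 log units; beyond the scatter) and an at least 2.6-fold higher number from compound 2 to compound 3 (0.42 log units; beyond the scatter), both weakening. Compound 4 `CCOC(=O)c1c(C)nc(-c2cccc(C#N)c2)n1OCc1ccc(Br)cc1` makes the change (4-bromophenyl in place of carboxymethyl on a saturated chain carbon bound to an oxygen on an aromatic ring), removing the carboxy group that marks the weakest member here. A step back toward the region of compound 1 and compound 2 is therefore expected, estimated as an at least 6.0-fold lower number from compound 3 to compound 4 (0.77 log units; beyond the scatter). Compound 4 is expected at about 5000 nM, within 1500 nM to 20000 nM.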

Compound 4, half-maximal inhibitory concentration: 24600 nM
Compound 4: middle estimate off by 4.9-fold (0.69 log units), on the low side; measured number outside the range, above it.
By their numbers in this assay, from the lowest: compounds 1 and 2 (each within the scatter of the next); then compound 4. At a limit, above all of these: compound 3.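

At this position, replacing the carboxymethyl group does not by itself restore the level of the ester and alcohol side chains: this assay shows a 2.2-fold higher number from compound 2 to compound 4 (0.33 log units; beyond the scatter) and a 3.6-fold higher number from compound 1 to compound 4 (0.56 log units; beyond the scatter). A side chain ending in 4-bromophenyl, with no carboxy group, therefore also reads on the weak side of compound 1 and compound 2. Compound 3 stands only at a limit, and the step to its neighbour is an at least 1.2-fold lower number from compound 3 to compound 4 (0.08 log units; that floor lies within the scatter), so its size stays unsettled: the limit of > 30000 nM in this assay, at which 1 of the 4 values shown sits.

Whether the bromine or the aromatic ring accounts for the rise stays open, since an unsubstituted benzyl group would be needed to separate them. On these data alone, whether an amine or a longer chain at this position would read nearer compound 1 also stays open.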